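Bis(trifluoromethyl)benzenesulfonamide diamines: removing the tert-butyl group

A few compounds are considered here, and "the series" means these few. Any claim that something is new, unique, unknown or untested is made for them only; others in the source may bear on it.

Measured compounds in a functional assay on PANC-1 cells (Homo sapiens) for inhibition, read by MTT assay, with a stated time of 72 h; on this read-out lower numbers stand for stronger inhibition of growth and higher numbers for weaker inhibition of growth:
compound 1 `O=S(=O)(NCCCNCc1cccc2ccccc12)c1cc(C(F)(F)F)cc(C(F)(F)F)c1` gives 2700 nM
compound 2 `O=S(=O)(NCCCCNCc1ccc(Br)cc1)c1cc(C(F)(F)F)cc(C(F)(F)F)c1` gives 2200 nM
compound 3 `CC(C)(C)c1ccc(CNCCCNS(=O)(=O)c2cc(C(F)(F)F)cc(C(F)(F)F)c2)cc1` gives 2500 nM

Compound 3 stands second highest of the three numbers in this assay; compound 1 sits nearest, and all three numbers lie within the scatter of one another. Among the measured compounds shown here, the one step in the set that changes the aryl group on the saturated chain carbon bound to the amine nitrogen, a 1.1-fold lower number from compound 1 to compound 3 (0.03 log units; within the scatter), shows that swapping naphthalen-1-yl for 4-(tert-butyl)phenyl left the growth inhibition essentially unchanged.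

Compound 4 `O=S(=O)(NCCCNCc1ccccc1)c1cc(C(F)(F)F)cc(C(F)(F)F)c1` differs from compound 3 by hydrogen in place of tert-butyl on an aromatic carbon. For the measured compounds named here, no measured pair isolates the tert-butyl group itself, so the step from compound 3 to compound 4 has no direct precedent. The aryl variations seen so far, including the step from compound 1 to compound 3 and the number of compound 2, all sit within the scatter, so a step no larger than the scatter is the working expectation for this assay, with a modest lean toward a higher number because of the small gap between compound 3 and compound 1 in 2700 nM having gone the other way.

Compound 4 is expected to show 3200 nM in this assay, within the range 1600 nM to 6500 nM. The estimated step of a 1.3-fold higher number from compound 3 to compound 4 (0.11 log units; within the scatter) is thus expected to lie within the scatter.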

Compound 4, concentration for 50% growth inhibition: 16000 nM
The estimate for compound 4 lay 5.0-fold (0.70 log units) below the measured number, outside the stated range (above it).
By their numbers in this assay, from the lowest: compounds 2, 3 and 1 (each within the scatter of the next); then compound 4.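

In this assay, hydrogen in place of tert-butyl on the aromatic carbon weakens growth inhibition, with a 6.4-fold higher number from compound 3 to compound 4 (0.81 log units; beyond the scatter), so this position is not as indifferent as the earlier aryl swaps, all within the scatter, suggested. The unsubstituted phenyl also stands apart from the fused aryl group, with a 5.9-fold higher number from compound 1 to compound 4 (0.77 log units; beyond the scatter), and from the brominated compound, with a 7.3-fold higher number from compound 2 to compound 4 (0.86 log units; beyond the scatter), although that last step also spans a change in the chain and does not isolate the aryl group. Nothing measured here bears on the reason for this loss.

Open, on these data alone, is whether a methyl or methoxy group in place of tert-butyl would hold the number near that of compound 3 or let it rise toward that of compound 4. Also open, as far as these compounds go, is how the step from the brominated compound divides between its bromine and its longer chain.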